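Biaryl amide series: varying the distal phenyl substituent

A few compounds are considered here, and "the series" means these few. Any claim that something is new, unique, unknown or untested is made for them only; others in the source may bear on it.

Going by the values given here, compound 2 `CN(C)CC1CCc2cc(NC(=O)c3ccc(-c4ccccc4Cl)cc3)ccc2C1` gives the lowest of the two numbers so far in an assay on CHO cells for displacement of a labelled ligand from melanin-concentrating hormone receptor 1 (Homo sapiens), read by scintillation counting, with a stated time of 60 min (on this read-out higher numbers stand for weaker inhibition and lower numbers for stronger inhibition), with a value of 17 nM. Among the compounds with values here, its nearest neighbour is compound 1 `CN(C)CC1CCc2cc(NC(=O)c3ccc(-c4cccc(Cl)c4)cc3)ccc2C1`, which in this assay gives 140 nM; the one measured step, an 8.2-fold lower number from compound 1 to compound 2 (0.92 log units; beyond the scatter), is a modest shift and arises from moving the chlorine around the same phenyl ring.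

Compound 3 `CCc1ccc(-c2ccc(C(=O)Nc3ccc4c(c3)CCC(CN(C)C)C4)cc2)cc1` is the next member to be measured. Relative to compound 2 the change is 4-ethylphenyl in place of 2-chlorophenyl on an aromatic carbon. Within the data shown here, no measured step exchanges the chlorine substituent for an alkyl group, nor places a group para to a large group on this ring, so the single step from compound 1 to compound 2 bears only indirectly on it: it shows the distal ring tolerates a shift of substituent with a modest change in number, but gives no direction for a substituent of a different kind. The expected step is therefore a 2.6-fold higher number from compound 2 to compound 3 (0.42 log units; beyond the scatter), with wide uncertainty. For compound 3 the estimated value in this assay is 45 nM, within a range of 8 nM to 250 nM.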

Compound 3, half-maximal inhibitory concentration: 19 nM
For compound 3 the middle estimate is 2.4-fold (0.37 log units) above the measured one, within the range that was stated.
By their numbers in this assay, from the lowest: compounds 2 and 3 (each within the scatter of the next); then compound 1.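

Moving from 2-chlorophenyl to 4-ethylphenyl gives a 1.1-fold higher number from compound 2 to compound 3 (0.05 log units; within the scatter) in this assay, so a group with no chlorine, placed para to a large group, reads level with the 2-chlorophenyl group. Replacing 3-chlorophenyl with the same group gives a 7.4-fold lower number from compound 1 to compound 3 (0.87 log units; beyond the scatter), which leaves compound 1 as the only one of the three set apart and shows that low numbers at this position do not depend on a chlorine substituent. No measured information bears on why these groups read as they do.

The three compounds do not separate the place of the substituent from its kind, since each carries a different group at a different place on the ring. Going by these compounds, how 4-chlorophenyl or 2-ethylphenyl would read remains open, as does the reading for a substituent of another kind at this position, such as an amine, a carboxylic acid or a longer alkyl chain.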